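The source may hold more compounds than are shown below. What is called first, only, known or untested is meant among the compounds shown, and "the series" means these compounds.

Measured in a functional assay on HT-29 cells (Homo sapiens) for antiproliferative activity; on this read-out lower numbers stand for stronger inhibition of growth and higher numbers for weaker inhibition of growth:
compound 1 `c1ccc(-c2cc(-c3ccsc3)cc(-c3ccccn3)n2)nc1`: 0.0027 ug/mL
compound 2 `c1ccc(-c2cc(-c3ccccn3)nc(-c3ccccn3)c2)cc1`: 0.0014 ug/mL
compound 3 `c1ccc(-c2cc(-c3cccs3)cc(-c3ccccn3)n2)nc1`: 0.0018 ug/mL

Compound 3, at 0.0018 ug/mL, lies within the scatter of both compound 1 and compound 2, so the three values form a single group with no readable order.

Compound 4 `c1ccc(-c2cc(-c3cccs3)cc(-c3cccnc3)n2)nc1` has the same atoms as compound 3, joined differently: pyridin-3-yl in place of pyridin-2-yl on an aromatic carbon. Pyridin-3-yl stands in place of pyridin-2-yl on an aromatic carbon of a six-membered aromatic ring with 1 nitrogen, next to the ring nitrogen.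

The measured steps are a 1.9-fold lower number from compound 1 to compound 2 (0.29 log units; within the scatter), a 1.5-fold lower number from compound 1 to compound 3 (0.18 log units; within the scatter) and a 1.3-fold higher number from compound 2 to compound 3 (0.11 log units; within the scatter), and each lies within the scatter. They exchange only thiophen-3-yl, thiophen-2-yl and phenyl. None of them removes a pyridin-2-yl group, and all three measured compounds carry two such groups, so the data do not test this change and give no size for it. Alone among these compounds, compound 4 carries only one pyridin-2-yl group. Starting from compound 3 at 0.0018 ug/mL, a move beyond the scatter towards a higher number in this assay is expected, with much uncertainty in its size. The expected step is a 110-fold higher number from compound 3 to compound 4 (2.05 log units; beyond the scatter). For compound 4 the estimated value is 0.2 ug/mL. The expected range for compound 4 runs from 0.005 ug/mL to 3 ug/mL.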

Compound 4, concentration for 50% growth inhibition: 0.19 ug/mL
Beside the measured number, compound 4's estimate is 1.1-fold (0.02 log units) above it, within the range that was stated.
By their numbers in this assay, from the lowest: compounds 2, 3 and 1 (each within the scatter of the next); then compound 4.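

In this assay the exchange of pyridin-2-yl for pyridin-3-yl gives a 110-fold higher number from compound 3 to compound 4 (2.02 log units; beyond the scatter), even though the two groups have the same heavy atoms and the same counts of hydrogen-bond donors and acceptors. The earlier compounds varied only thiophen-3-yl, thiophen-2-yl and phenyl, all with steps within the scatter, so this is the first sign that the read-out responds strongly to a change in the compounds shown, and here that change is only in how a group of identical atoms is joined to the aromatic carbon next to the ring nitrogen. Nothing available gives a reason for a step of this size.

On these data alone, this rests on a single pair, so it remains open whether the same exchange would have a similar effect in the phenyl series of compound 2 or the thiophen-3-yl series of compound 1, or whether the other pyridin-2-yl group, which stays in compound 4, is equally sensitive. As far as these compounds go, it is also open how this place would respond to pyridin-4-yl, to an unsubstituted phenyl, or to a pyridin-2-yl group carrying an amine.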